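A few compounds are considered here, and "the series" means these few. Any claim that something is new, unique, unknown or untested is made for them only; others in the source may bear on it.

- Compound 1 `COc1cc(N2CCC(CC(=O)N3CCOCC3)CC2)ccc1Nc1nc(NC2CCCCC2)c2nc[nH]c2n1`: 70 nM
- Compound 2 `COc1cc(N2CCC(CC(=O)N3CCN(C)CC3)CC2)ccc1Nc1nc(NC2CCCCC2)c2nc[nH]c2n1`: 65 nM

In a functional assay on HCT-116 cells (Homo sapiens) for inhibition (on this read-out lower numbers stand for an effect already at smaller amounts and higher numbers for an effect only at larger amounts of compound), compound 2 gives 65 nM and compound 1 gives 70 nM, so the two stand level within the scatter. Compound 3 `CCN(CC)CC1CCN(c2ccc(Nc3nc(NC4CCCCC4)c4nc[nH]c4n3)c(OC)c2)CC1` has not yet been measured. It carries diethylamino in place of (4-methylpiperazin-1-yl)carbonyl on a saturated chain carbon bound to a saturated ring carbon.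

Among the measured compounds shown here, only one measured step bears on this change. That step, a 1.1-fold lower number from compound 1 to compound 2 (0.03 log units; within the scatter), put 4-methylpiperazin-1-yl in place of morpholin-4-yl on a carbonyl carbon and stayed within the scatter. For the measured compounds named here, the carbonyl remained there, whereas here it goes, and no measured compound shows that loss. The step is therefore only a loose guide, and no shift beyond the scatter is expected in this assay, in either direction, though the uncertainty is wide. The expected change is a 1.1-fold lower number from compound 2 to compound 3 (0.03 log units; within the scatter). For compound 3 the estimated value is 60 nM, with an expected range from 15 nM to 220 nM.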

Compound 3, half-maximal effective concentration: 55 nM
Compound 3: the middle estimate sits 1.1-fold (0.04 log units) above what was measured; measured number inside the range.
By their numbers in this assay, from the lowest: compounds 3, 2 and 1 (each within the scatter of the next).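

In this assay, the carbonyl on this saturated chain carbon bound to a saturated ring carbon proves dispensable: diethylamino in place of (4-methylpiperazin-1-yl)carbonyl gives a 1.2-fold lower number from compound 2 to compound 3 (0.07 log units; within the scatter) and diethylamino in place of (morpholin-4-yl)carbonyl gives a 1.3-fold lower number from compound 1 to compound 3 (0.10 log units; within the scatter) in this series. The position therefore holds a group with no ring and fewer heavy atoms as well as the larger ring-bearing groups, with all three compounds standing level. No data on why the read-out stays level at this position are available here.

On these data alone, whether a carboxylic acid or a primary amine at this place would also stay level remains open. So does whether a longer chain carrying the diethylamino group, or pyrrolidine in its stead, would leave the number unchanged.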